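Pyridinyl Replaces Cyclopropyl: Clearance Outlook for Compound 4

A few compounds are considered here, and "the series" means these few. Any claim that something is new, unique, unknown or untested is made for them only; others in the source may bear on it.

Measured so far:
compound 1 `Nc1ccc(S(=O)(=O)N2CCN(c3ncc(C(O)(C(F)(F)F)C(F)(F)F)cc3Br)CC2)cn1` — 32 mL.min-1.g-1
compound 2 `Nc1ccc(S(=O)(=O)N2CCN(c3ncc(C(O)(C(F)(F)F)C(F)(F)F)cc3C3CC3)CC2)cn1` — 27 mL.min-1.g-1
compound 3 `Cn1cc(-c2cc(C(O)(C(F)(F)F)C(F)(F)F)cnc2N2CCN(S(=O)(=O)c3ccc(N)nc3)CC2)cn1` — 44 mL.min-1.g-1

Of the compounds shown here, three have been tested in an ADME assay (liver) for metabolic stability, with Liver microsome (Rattus norvegicus) as the target, using microsomes and NADPH, with a stated time of 30 min, tested at 1 uM; a higher number here means faster removal of the compound, a lower number slower removal. Compound 2 gives the lowest of the three numbers, but its distance to either neighbour lies within the scatter: a 1.2-fold lower number from compound 1 to compound 2 (0.07 log units; within the scatter), and a 1.6-fold higher number from compound 2 to compound 3 (0.21 log units; within the scatter). The two substituted compounds are likewise close, since a 1.4-fold higher number from compound 1 to compound 3 (0.14 log units; within the scatter).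

Compound 4 `Nc1ccc(S(=O)(=O)N2CCN(c3ncc(C(O)(C(F)(F)F)C(F)(F)F)cc3-c3cccnc3)CC2)cn1` is the next member. Its change from compound 2 is pyridin-3-yl in place of cyclopropyl on an aromatic carbon. The step that bears most on it is the one in which a ring also replaced the cyclopropyl, a 1.6-fold higher number from compound 2 to compound 3 (0.21 log units; within the scatter), which moved the number upward but not beyond the scatter; the step of a 1.4-fold higher number from compound 1 to compound 3 (0.14 log units; within the scatter) points the same way. Compound 4 is therefore expected to sit near compound 2 or slightly above it, with an expected step of a 1.3-fold higher number from compound 2 to compound 4 (0.11 log units; within the scatter) that should not clear the scatter. The estimate for compound 4 is 35 mL.min-1.g-1, expected to fall between 18 mL.min-1.g-1 and 70 mL.min-1.g-1.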

Compound 4, intrinsic clearance in microsomes: 20 mL.min-1.g-1
Compound 4: middle estimate off by 1.8-fold (0.24 log units), on the high side; the range from low to high includes it.
By their numbers in this assay, from the lowest: compounds 4, 2, 1 and 3 (each within the scatter of the next, the first and the last beyond it).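

At this position, ortho to a large group and meta to the 2,2,2-trifluoro-1-hydroxy-1-(trifluoromethyl)ethyl group, two aromatic ring substituents do not read alike in this assay: the change shows a 2.2-fold lower number from compound 3 to compound 4 (0.34 log units; beyond the scatter), the only step among these four compounds that clears the scatter. Compound 3 alone could have suggested that an aromatic ring here raises the number, but pyridin-3-yl cannot be told apart from the smaller groups, with a 1.4-fold lower number from compound 2 to compound 4 (0.13 log units; within the scatter) and a 1.6-fold lower number from compound 1 to compound 4 (0.20 log units; within the scatter) as its other two steps. Nothing given here explains the gap between the two rings.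

The compounds shown leave open whether the ring nitrogen of pyridin-3-yl matters, which a phenyl group on the same carbon would test. They also leave open whether its placement matters, which pyridin-2-yl or pyridin-4-yl would test.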